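This account rests on a few compounds, and the source may have more. Where it says the series, first, only, none or still open, it means among the compounds named here.

Measured in an assay on membranes from Cerebral cortex for displacement of a labelled ligand from Neuronal acetylcholine receptor; alpha4/beta2 (Rattus norvegicus), with a stated time of 5 min; on this read-out lower numbers stand for stronger inhibition and higher numbers for weaker inhibition:
compound 1 `CN1CCC[C@H]1[C@H]1COc2ccc(N)cc2O1` gives 140 nM
compound 2 `CN1CCC[C@H]1[C@@H]1COc2cc(N)ccc2O1` gives 86000 nM
compound 3 `CN1CCC[C@H]1[C@H]1COc2cc(N)ccc2O1` gives 74000 nM

Compound 3 stands second highest of the three numbers in this assay. Among the compounds with values here, the only single-point step among the measured compounds is a 1.2-fold lower number from compound 2 to compound 3 (0.07 log units; within the scatter); the two compounds differ only in configuration the fact that compounds 2 and 3 differ only in the configuration as drawn and the step lies within the scatter. Compound 1 is the outlier of the set, its number far lower than that of compound 3 in this assay.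

Compound 4 `CN1CCC[C@H]1[C@H]1COc2cc([N+](=O)[O-])ccc2O1` differs from compound 3 by nitro in place of amino on an aromatic carbon. Within the data shown here, no measured step touches the aromatic substituent, so the single step on record carries no information on this change. Compound 3 is therefore taken as the anchor, and compound 4 is expected to show no change at the digits printed from compound 3 to compound 4 (within the scatter), no step beyond the scatter, with a wide range. The estimate for compound 4 in this assay is 74000 nM, expected between 20000 nM and 300000 nM.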

Compound 4, inhibition constant: > 100000 nM
Compound 4: only a limit was reported (the forecaster's own chance of this, stated with the estimate: 30%); at least 1.3-fold (0.13 log units) between middle value and limit.
By their numbers in this assay, from the lowest: compound 1; then compounds 3 and 2 (each within the scatter of the next). At a limit, above all of these: compound 4.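

In this assay, nitro in place of amino on this aromatic carbon gives an at least 1.3-fold higher number from compound 3 to compound 4 (0.13 log units; that floor lies within the scatter), so the first change recorded at this position brings no lower number. For compound 4 the reading is a limit, > 100000 nM, not a number. The step therefore fixes a direction only as a floor, and its true size cannot be read.

Going by these compounds, how far compound 4 really lies from compound 3 stays open. Also open, on these data alone, is whether a methoxy group, a carboxylic acid or a dimethylamino group on the same carbon would shift the number beyond the scatter.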